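Urea series: piperidin-1-yl replacing tert-butyl on the aryl

The source may report more compounds than this note shows. Statements on the series, on what has been measured and on what is new or still open speak of the compounds shown alone.

Measured in an assay on isolated protein for inhibition of transient receptor potential cation channel subfamily V member 1 (Homo sapiens), read by calcium flux; a higher number here means a weaker inhibitor, a lower number a stronger inhibitor:
compound 1 `CC(C)(C)c1cccc2c1CCC2NC(=O)Nc1cccc2[nH]ncc12` gives 14 nM
compound 2 `O=C(Nc1cccc2[nH]ncc12)NC1CCc2cccnc21` gives 1350 nM
compound 3 `O=C(Nc1cccc2[nH]ncc12)NC1CCOc2cc(C(F)(F)F)ccc21` gives 11 nM

Compound 1 sits close to compound 3, the two numbers within the scatter of each other, while compound 2 lies far above both, beyond the scatter. Compound 4 `O=C(Nc1cccc2[nH]ncc12)NC1CCc2c1cccc2N1CCCCC1` is not yet measured. It differs from compound 1 in one place: piperidin-1-yl in place of tert-butyl on an aromatic carbon. Going by the values given here, no step between measured compounds covers this change, and compound 2, the only compound without a group at that position, differs in more than one place, so it is no clean guide. A substituent remains on the aromatic carbon, so a small upward step in this assay, close to the scatter, is expected: a 2.9-fold higher number from compound 1 to compound 4 (0.46 log units; beyond the scatter). Compound 4 is estimated at 40 nM, range 10 nM to 200 nM.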

Compound 4, half-maximal inhibitory concentration: 10 nM
Compound 4: the middle estimate sits 4.0-fold (0.60 log units) above what was measured; the range from low to high includes it.
By their numbers in this assay, from the lowest: compounds 4, 3 and 1 (each within the scatter of the next); then compound 2.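

In this assay, going by these compounds alone, replacing tert-butyl with piperidin-1-yl on this aromatic carbon gives a 1.4-fold lower number from compound 1 to compound 4 (0.15 log units; within the scatter), the first clean reading at this position. The position therefore accommodates a group with one six-membered non-aromatic ring and a hydrogen-bond acceptor as well as the ring-free tert-butyl, at least in this pair. Nothing available explains why the two groups read alike. From the compounds shown here alone, whether this holds for morpholin-4-yl, a primary amine or a carboxylic acid on the same carbon remains open. Also open, going by these compounds, is how the unsubstituted carbon reads on the core of compound 1.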